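Replacing the sulfamoyl group of compound 3

The compounds below may be only part of what the source reports. "The series", "measured", "known", "first", "only" and "open" are said of these compounds alone.

Of the compounds shown here, three sharing one core have so far been read in an ADME assay on microsomes from liver (Homo sapiens) for metabolic stability (on this read-out lower numbers stand for a shorter-lived compound and higher numbers for a longer-lived compound), and their values sit close together. Compound 1 `NS(=O)(=O)CC(=O)NCCSc1nonc1/C(=N/O)Nc1cccc(Cl)c1` returned only a limit of the assay at > 3 h and no number. Compound 2 `NS(=O)(=O)CC(=O)NCCSc1nonc1/C(=N/O)Nc1ccc(F)c(C(F)F)c1` gives 2.77 h and compound 3 `NS(=O)(=O)CC(=O)NCCSc1nonc1/C(=N/O)Nc1ccc(F)c(Br)c1` gives 2.37 h so these two stand level within the scatter.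

Compound 4 `CS(=N)(=O)CC(=O)NCCSc1nonc1/C(=N/O)Nc1ccc(F)c(Br)c1` has yet to be measured. Its change is a group of 4 heavy atoms (1 carbon, 1 nitrogen, 1 oxygen, 1 sulfur; no ring) in place of a group of 4 heavy atoms (1 nitrogen, 2 oxygen, 1 sulfur; no ring), on a saturated chain carbon bound to a carbonyl carbon on a saturated chain carbon bound to a carbonyl carbon, where the sulfamoyl leaves and a group with no common name enters.

The measured steps are an at least 1.0-fold lower number from compound 1 to compound 2 (0.03 log units; that floor lies within the scatter) and an at least 1.2-fold lower number from compound 1 to compound 3 (0.10 log units; that floor lies within the scatter) and a 1.2-fold lower number from compound 2 to compound 3 (0.07 log units; within the scatter) and all of them stay within the scatter, although the first two rest on a limit. None of them touches the sulfamoyl, so the data give no direct size for this exchange. They show only that the series has held close together so far, and compound 3 at 2.37 h is the natural anchor for the expectation. The estimated step is a 1.0-fold lower number from compound 3 to compound 4 (0.01 log units; within the scatter) and is expected to stay within the scatter, with no firm direction. In this assay compound 4 is expected at 2.3 h with an estimated range from 1.3 h to 3 h for repeat measurements.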

Compound 4, half-life: 2.65 h
Compound 4: middle estimate off by 1.2-fold (0.06 log units), on the low side; measured number inside the range.
By their numbers in this assay, from the lowest: compounds 3, 4 and 2 (each within the scatter of the next). At a limit, above all of these: compound 1.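

The exchange of sulfamoyl for the new group, on a saturated chain carbon bound to a carbonyl carbon, gives a 1.1-fold higher number from compound 3 to compound 4 (0.05 log units; within the scatter) in this assay, and it is the first step shown at this position, since the earlier steps all concern the aromatic substituents on the amine nitrogen. The two groups have the same count of heavy atoms, donors and acceptors and no net charge, and with the 3-bromo-4-fluorophenyl group in place, this read-out does not separate them. Compound 1 stands at a limit of the assay, so a longer-lived compound might not be sized as a number in this series: the limit of > 3 h in this assay, at which 1 of the 4 values shown sits.

The compounds shown leave open whether the same exchange would stay within the scatter alongside 3-chlorophenyl or 3-(difluoromethyl)-4-fluorophenyl. They also leave open how this read-out would respond on this carbon to a group of another kind, such as a carboxylic acid, a primary amine or a longer chain ending in the sulfamoyl.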